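The source may hold more compounds than are shown below. What is called first, only, known or untested is meant among the compounds shown, and "the series" means these compounds.

Of the compounds shown here, two have numbers so far in a functional assay on MCF7 cells (Homo sapiens) for cytotoxicity, read by MTT assay, with a stated time of 48 h; on this read-out higher numbers stand for weaker inhibition and lower numbers for stronger inhibition. Compound 1 (`C/C(=N\NC(=S)Nc1ccc(F)cc1)c1ccccn1`) gives 1.2 nM. Compound 2 (`CC(=NNC(=S)Nc1ccc(I)cc1)c1ccccn1`) gives 6.6 nM, the higher of the two numbers, and its gap to compound 1 lies beyond the usual scatter. Compound 3 (`CC(=NNC(=S)Nc1ccc(F)cc1)c1ccccn1`) has not yet been measured in this assay. It differs from compound 2 by one change, fluoro in place of iodo on an aromatic carbon. Among the measured compounds shown here, no step between measured compounds isolates this change, so the expectation rests on a single comparison. Compound 1 also carries fluoro and gives 1.2 nM, so a fall in the number beyond the scatter is expected, ending close to that value. The expected step is a 5.1-fold lower number from compound 2 to compound 3 (0.71 log units; beyond the scatter). In this assay the estimated value for compound 3 is 1.3 nM, with an expected range of 0.7 nM to 3 nM.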

Compound 3, half-maximal inhibitory concentration: 1.2 nM
For compound 3 the middle estimate is 1.1-fold (0.03 log units) above the measured one, within the range that was stated.
By their numbers in this assay, from the lowest: compounds 1 and 3 (each within the scatter of the next); then compound 2.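

In this assay, fluoro in place of iodo on this aromatic carbon now stands as a single isolated change, with a step beyond the scatter: a 5.5-fold lower number from compound 2 to compound 3 (0.74 log units; beyond the scatter). The earlier comparison could not show this cleanly, since the two compounds then measured also differed in how the double bond was drawn. The other new step, no change at the digits printed from compound 1 to compound 3 (within the scatter), joins two drawings with the same atoms and bonds, so it gives no second reading of a substituent change, and the only point on which they differ is: the fact that one of compounds 1 and 3 is drawn with a defined configuration and the other without, at the place where they differ

With only iodo and fluoro at this carbon, the two values give no trend across substituents. As far as these compounds go, how chloro, bromo, methoxy, an amine or a carboxylic acid at the same place would read remains open.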